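Removing the Fluoro Substituent from Compound 2

The source may hold more compounds than are shown below. What is called first, only, known or untested is meant among the compounds shown, and "the series" means these compounds.

Of the compounds shown here, two have been measured in a physicochemical assay for lipophilicity, read by HPLC, at pH 7.4; on this read-out higher numbers stand for higher lipophilicity and lower numbers for lower lipophilicity. Compound 1, `O=C(Nc1ccc(F)c(-c2nc3ncccc3o2)c1)c1ccoc1`, gives 2.4 in this assay. Compound 2, `Cc1ccoc1C(=O)Nc1ccc(F)c(-c2nc3ncccc3o2)c1`, gives 2.9 in this assay and so stands highest of the two numbers; its nearest neighbour is compound 1, from which it is separated by a number 0.50 log units higher from compound 1 to compound 2 (beyond the scatter). Among the measured compounds shown here, that measured step concerns the 3-methylfuran-2-yl in place of furan-3-yl on a carbonyl carbon and is the only step recorded so far.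

Compound 3, `Cc1ccoc1C(=O)Nc1cccc(-c2nc3ncccc3o2)c1`, is not yet measured in this assay. It differs from compound 2 as follows: hydrogen in place of fluoro on an aromatic carbon. For the measured compounds named here, no measured pair in this set shows this change, so the one recorded step offers no direct guide to its size or direction. Given that the carbonyl-bearing part of compound 2 is kept unchanged, compound 3 is expected to lie close to compound 2, with a step of a number 0.20 log units lower from compound 2 to compound 3 (within the scatter), which does not clearly exceed the scatter. Compound 3 is therefore estimated at 2.7, with a range from 2.3 to 3.1.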

Compound 3, distribution coefficient: 2.9
Beside the measured number, compound 3's estimate is 0.20 log units below it, and the stated range covers the measured number.
By their numbers in this assay, from the lowest: compound 1; then compounds 2 and 3 (each within the scatter of the next).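

In this assay, hydrogen in place of fluoro on an aromatic carbon gives no change at the digits printed from compound 2 to compound 3 (within the scatter), so this one change does not separate compound 2 from compound 3 on this read-out. Among the compounds shown here, this is the first view of the aromatic ring of carbon only, at the place ortho to a group of 9 heavy atoms and para to a group of 9 heavy atoms, whereas the earlier step, a number 0.50 log units higher from compound 1 to compound 2 (beyond the scatter), concerned the other end of the molecule, the group on the carbonyl carbon, and lay beyond the scatter. Nothing measured here offers an explanation of why the fluoro-to-hydrogen step lies within the scatter.

As far as these compounds go, the pair covers only fluoro and hydrogen, so it remains open whether a larger or differently built group at this place, such as chloro, methoxy, an amine or a carboxylic acid, would also stay within the scatter of compound 3. From the compounds shown here alone, it also remains open whether the same change would give a step of similar size with another group on the carbonyl carbon, such as the furan-3-yl of compound 1.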